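This account rests on a few compounds, and the source may have more. Where it says the series, first, only, none or still open, it means among the compounds named here.

Measured in a functional assay on PC-3 cells (Homo sapiens) for antiproliferative activity, read by MTT assay, with a stated time of 48 h; on this read-out higher numbers stand for weaker inhibition and lower numbers for stronger inhibition:
- Compound 1 `COc1ccc(CN(C(=O)COc2cc(OC)c(OC)c(OC)c2)c2cc(OC)c(OC)c(OC)c2)cc1`: > 80000 nM, a limit of the assay and not a number
- Compound 2 `COc1ccc(CN(C(=O)COc2ccc(OC)cc2)c2cc(OC)c(OC)c(OC)c2)cc1`: 66400 nM

For the measured compounds named here, compound 2 holds the only actual number so far, so there is no series of values in which to rank it. Compound 3 `COc1ccc(CN(C(=O)COc2ccccc2)c2cc(OC)c(OC)c(OC)c2)cc1` has not yet been measured. It differs from compound 2 in one place: hydrogen in place of methoxy on an aromatic carbon. Hydrogen takes the place of methoxy on an aromatic carbon, para to a large group, so 4-methoxyphenoxy becomes phenoxy.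

Going by the values given here, one measured step bears on this change: an at least 1.2-fold lower number from compound 1 to compound 2 (0.08 log units; that floor lies within the scatter). That step also removes methoxy groups from the same aromatic ring. From the compounds shown here alone, compound 1 has only a limit, so the true size of the step remains unknown. This single step is thin evidence, but it gives no reason to expect a change beyond the scatter in this assay, and no direction can be favoured. The expected result is a 1.1-fold lower number from compound 2 to compound 3 (0.04 log units; within the scatter), which would lie within the scatter. For compound 3 the estimated value is 60000 nM, with an expected range from 30000 nM to 100000 nM.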

Compound 3, half-maximal inhibitory concentration: 19700 nM
Compound 3: the middle estimate sits 3.0-fold (0.48 log units) above what was measured; the measured number lies below the stated range.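

In this assay, for the compounds shown here, hydrogen in place of methoxy on an aromatic carbon, para to a large group, gives the first change that can be read as a real difference between two actual numbers (a 3.4-fold lower number from compound 2 to compound 3 (0.53 log units; beyond the scatter)). The plain phenyl also stands apart from the fully substituted ring (an at least 4.0-fold lower number from compound 1 to compound 3 (0.60 log units; beyond the scatter)), so compound 3 has the lowest number of the three, with both of its steps beyond the scatter, and on this ring fewer methoxy groups go with stronger inhibition in these compounds. The true size of that second step stays unknown, since compound 1 carries a limit and not a number: the limit of > 80000 nM in this assay, at which 1 of the 3 values shown sits.

From the compounds shown here alone, what remains open is whether the gain comes from the loss of the methoxy group as such, or whether a small group at the same place, such as fluorine, chlorine, methyl or hydroxyl, would give a similar number. The compounds shown also leave untouched the methoxy groups on the other two rings of the shared core, so nothing here says how those groups contribute to the activity.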